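Aryl exchange in an amide series: macrophage cytotoxicity notes

This account rests on a few compounds, and the source may have more. Where it says the series, first, only, none or still open, it means among the compounds named here.

Compound 1 `COc1cccc(CNC(=O)c2c([N+](=O)[O-])noc2-c2ccc([N+](=O)[O-])cc2)c1` has in an ADME assay on J774.A1 cells (Mus musculus) for cytotoxicity, read by MTT assay, with a stated time of 48 h (on this read-out higher numbers stand for lower toxicity in this test and lower numbers for higher toxicity in this test), only the entry "not determined" (no result reported), so nothing is known of where it stands. Among the compounds with values here, the only measured member is compound 2 `CCCNC(=O)c1c([N+](=O)[O-])noc1-c1ccc([N+](=O)[O-])cc1`, which in this assay gives 76200 nM. Compound 3 `COc1cccc(CNC(=O)c2c([N+](=O)[O-])noc2-c2ccc(Cl)cc2Cl)c1` differs from compound 1 by 2,4-dichlorophenyl in place of 4-nitrophenyl on an aromatic carbon. Within the data shown here, no measured pair isolates this change, so the size of the step in this assay cannot be read from the data; a modest shift toward higher toxicity than compound 2 shows is expected, though it may lie within the scatter. Compound 3 is expected to give 40000 nM in this assay, in the range 10000 nM to 150000 nM.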

Compound 3, half-maximal cytotoxic concentration: 61200 nM
For compound 3 the middle estimate is 1.5-fold (0.18 log units) below the measured one; measured number inside the range.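

In this assay no step can be read between compound 1 and compound 3. No outside data bear on this result. The compounds shown leave open what exchanging 4-nitrophenyl for 2,4-dichlorophenyl does to macrophage cytotoxicity.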